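The compounds below may be only part of what the source reports. "The series", "measured", "known", "first", "only" and "open" are said of these compounds alone.

Notes on the shared core: compound 1 `COc1ccc(Nc2nc(-c3ccncc3)cs2)cc1OC` in a functional assay on RCC4 cells (Homo sapiens) for inhibition, read by XTT assay, with a stated time of 4 days (on this read-out higher numbers stand for weaker inhibition and lower numbers for stronger inhibition), gives 24500 nM; compound 3 `COc1ccc(Nc2nc(-c3ccncc3)cs2)cc1` gives 14100 nM; compound 2 `CCc1cc(-c2csc(Nc3cccc(C)c3)n2)ccn1` gives 6460 nM. Compound 3 stands second highest of the three numbers, nearest to compound 1 and within the scatter of it, furthest from compound 2, whose lower number lies beyond the scatter. For the measured compounds named here, the one single-change step measured, a 1.7-fold lower number from compound 1 to compound 3 (0.24 log units; within the scatter), is within the scatter. Compound 4 `Cc1ccc(Nc2nc(-c3ccncc3)cs2)cc1` differs from compound 3 by methyl in place of methoxy on an aromatic carbon. Going by the values given here, no measured step tests this change directly; compound 2 differs from compound 3 in more than one place, so only its two values can be compared. The expected step is therefore a 1.2-fold lower number from compound 3 to compound 4 (0.07 log units; within the scatter), nothing beyond the scatter. Compound 4 is estimated at 12000 nM, between 5000 nM and 30000 nM.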

Compound 4, half-maximal inhibitory concentration: 2510 nM
The estimate for compound 4 lay 4.8-fold (0.68 log units) above the measured number, outside the stated range (below it).
By their numbers in this assay, from the lowest: compound 4; then compound 2; then compounds 3 and 1 (each within the scatter of the next).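

Methyl in place of methoxy on an aromatic carbon, para to a large group, gives a 5.6-fold lower number from compound 3 to compound 4 (0.75 log units; beyond the scatter) in this assay. For the compounds shown here, the only earlier single change, a 1.7-fold lower number from compound 1 to compound 3 (0.24 log units; within the scatter), stayed within the scatter, so this is the first step in these compounds to show that a change on this ring can move the number beyond it. Methyl is the group here that gives the lowest number of the compounds shown.

Going by these compounds, whether an amine, a chlorine atom or a longer chain such as propyl at this position would give a number nearer that of compound 4 or that of compound 3 remains open. No evidence at hand accounts for the size of this step.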